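Cytotoxicity limits in a nitrobenzamide series

A few compounds are considered here, and "the series" means these few. Any claim that something is new, unique, unknown or untested is made for them only; others in the source may bear on it.

Measured so far, in an ADME assay on Raji cells (Homo sapiens) for cytotoxicity, with a stated time of 72 h; on this read-out higher numbers stand for an effect only at larger amounts of compound and lower numbers for an effect already at smaller amounts:
compound 1 `Cc1cc(NC(=O)c2cc([N+](=O)[O-])ccc2Cl)cc(-c2nc3ccccc3s2)c1O`, > 25000 nM
compound 2 `Cc1ccc(-c2nc3ccccc3o2)cc1NC(=O)c1cc([N+](=O)[O-])ccc1Cl`, > 14000 nM
compound 3 `O=C(Nc1ccc(O)c(-c2nc3ccccc3s2)c1)c1cc([N+](=O)[O-])ccc1Cl`, > 25000 nM

Every value shown is a limit of the assay and not a number. For compound 1 the value is a limit. For compound 2 the value is also a limit. For compound 3 the value is again a limit. Within the data shown here, the single one-place step among them, a step that the two limits leave unreadable from compound 1 to compound 3, is therefore unreadable. Compound 2 stands at the limit of > 14000 nM in this assay, at which 1 of the 3 values shown sits, while the limit of > 25000 nM in this assay, at which 2 of the 3 values shown sit, holds the other two values; nothing here orders the three compounds.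

The next compound, compound 4 `COc1ccc(-c2nc3ccccc3o2)cc1NC(=O)c1cc([N+](=O)[O-])ccc1Cl`, differs from compound 2 by methoxy in place of methyl on an aromatic carbon. Among the measured compounds shown here, no measured step bears on this change, and the one measured step is itself unreadable, so the expectation rests only on compound 2 sitting at a limit.

Compound 4 is expected to remain at a limit, with a step that the limit leaves unreadable from compound 2 to compound 4 that is estimated as none beyond the scatter. The estimate for compound 4 in this assay is 20000 nM, within 5000 nM to 60000 nM.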

Compound 4, half-maximal effective concentration in the Raji assay: > 25000 nM
Compound 4 was reported as a limit; the forecaster's own chance of this, stated with the estimate: 85%; middle value at least 1.2-fold (0.09 log units) away from the limit.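

Among these compounds, in the Raji assay compound 2 and compound 4 both sit at limits of the assay, so no step between them can be read. In a physicochemical assay for solubility, read by spectrophotometry, in phosphate buffer, measured as kinetic solubility, with a stated time of 18 h, at pH 7.4 (a higher number here means a more soluble compound, a lower number a less soluble compound), compound 2 gives 310 nM and compound 4 gives 90 nM, with methoxy in place of methyl giving a 3.4-fold lower number from compound 2 to compound 4 (0.54 log units; beyond the scatter). The compounds shown leave open how any of them ranks in the Raji assay.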